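From 4-methoxyphenyl to (4-methoxyphenyl)amino on a carbonyl carbon

The compounds below may be only part of what the source reports. "The series", "measured", "known", "first", "only" and "open" are said of these compounds alone.

In a functional assay on HT-29 cells (Homo sapiens) for inhibition, read by MTT assay, with a stated time of 48 h (on this read-out lower numbers stand for stronger inhibition and higher numbers for weaker inhibition), compound 1 `COc1ccc(-n2c(S)nnc2-c2cc(OC)c(OC)c(OC)c2)cc1` is recorded only as a limit, > 60000 nM. Compound 2 `COc1ccc(C(=O)CSc2nnc(-c3cc(OC)c(OC)c(OC)c3)n2-c2ccc(OC)cc2)cc1` is likewise recorded only as a limit, > 60000 nM, so no exact number fixes its strength. The record so far is short: the limit of > 60000 nM in this assay, at which 2 of the 2 values shown sit. Going by the values given here, the only measured step is a step that the two limits leave unreadable from compound 1 to compound 2, which gives no size to carry forward.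

Compound 3 `COc1ccc(NC(=O)CSc2nnc(-c3cc(OC)c(OC)c(OC)c3)n2-c2ccc(OC)cc2)cc1` keeps the rest of compound 2 and changes one group, with (4-methoxyphenyl)amino in place of 4-methoxyphenyl on a carbonyl carbon.

Among the compounds with values here, no measured step shows a gain in strength, so no step beyond the scatter is expected in this assay. This expectation rests on compound 2, whose result is a limit of > 60000 nM. The estimated step is a number no higher from compound 2 to compound 3 (the limit leaves the size open), and another limit is the most likely report, although a measurable value cannot be ruled out. For compound 3 the estimated value is 60000 nM, with an expected range of 15000 nM to 120000 nM.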

Compound 3, half-maximal inhibitory concentration: 45300 nM
Estimate against measurement, compound 3: 1.3-fold (0.12 log units) above; the measured number falls inside the stated range.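

Going by these compounds alone, at this carbonyl carbon, in this assay, putting (4-methoxyphenyl)amino in place of 4-methoxyphenyl yields the first exact number in this small set, but the change can be stated only as an at least 1.3-fold lower number from compound 2 to compound 3 (0.12 log units; that floor lies within the scatter). Measured against the compound with hydrogen on the sulfur, the whole ((4-methoxyphenyl)carbamoyl)methyl group gives an at least 1.3-fold lower number from compound 1 to compound 3 (0.12 log units; that floor lies within the scatter), while the step from compound 1 to compound 2 cannot be read, as both ends are limits. As far as these compounds go, the change adds a nitrogen and a hydrogen-bond donor and gives a measurable result, but its true size remains unknown, and most of the record still rests on a single limit: the limit of > 60000 nM in this assay, at which 2 of the 3 values shown sit.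

The compounds shown cannot separate the role of the amide hydrogen from that of the 4-methoxyphenyl ring attached to the nitrogen, and a small amine such as methylamino on the same carbonyl carbon would help to tell these apart. A phenylamino group without the methoxy, or a longer chain between the sulfur and the carbonyl, would show whether this position can give a much lower number at all.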